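Triazole substituent swap: alkyl chloride back to an aryl ring

The compounds below may be only part of what the source reports. "The series", "measured", "known", "first", "only" and "open" are said of these compounds alone.

Two compounds of the shared core have numbers in a functional assay on SW-620 cells (Homo sapiens) for antiproliferative activity, read by MTT assay, with a stated time of 72 h (on this read-out lower numbers stand for stronger inhibition and higher numbers for weaker inhibition), so far. Compound 1 `O=C1O[C@H]([C@@H](O)Cn2cc(-c3ccc(Br)cc3)nn2)C(OCc2ccccc2)=C1OCc1ccccc1` carries a 4-bromophenyl on the triazole and in this assay compound 1 gives 3760 nM. Going by the values given here, compound 2 `O=C1O[C@H]([C@@H](O)Cn2cc(CCCCl)nn2)C(OCc2ccccc2)=C1OCc1ccccc1` carries a 3-chloropropyl in the same place and in this assay compound 2 gives 68500 nM, the highest number of the two, with compound 1 as its only neighbour. Among the compounds with values here, the one step seen, an 18-fold higher number from compound 1 to compound 2 (1.26 log units; beyond the scatter), is large and beyond the scatter.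

Compound 3 `COc1ccc(-c2cn(C[C@H](O)[C@H]3OC(=O)C(OCc4ccccc4)=C3OCc3ccccc3)nn2)cc1` differs from compound 2 by 4-methoxyphenyl in place of 3-chloropropyl on an aromatic carbon. Within the data shown here, this reverses the direction of the only measured step, returning an aromatic ring to the position where compound 1 holds one, so a large drop in number, a 14-fold lower number from compound 2 to compound 3 (1.14 log units; beyond the scatter), is expected, roughly undoing the step from compound 1 to compound 2. Compound 3 is expected to give 5000 nM, with a range from 1500 nM to 20000 nM.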

Compound 3, half-maximal inhibitory concentration: 58200 nM
Compound 3: middle estimate off by 12-fold (1.07 log units), on the low side; measured number above the stated range.
By their numbers in this assay, from the lowest: compound 1; then compounds 3 and 2 (each within the scatter of the next).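

In this assay, an aromatic ring at this carbon is not enough on its own to give a low number: with 4-methoxyphenyl in place of 3-chloropropyl, the change is a 1.2-fold lower number from compound 2 to compound 3 (0.07 log units; within the scatter). The group carried on the phenyl ring counts for more here, since methoxy in place of bromo gives a 15-fold higher number from compound 1 to compound 3 (1.19 log units; beyond the scatter), which leaves compound 1 as the only one of the three set apart from the others. Nothing available here explains why bromo and methoxy differ on this ring.

Going by these compounds, it remains open whether the low number of compound 1 is specific to bromo or would also hold for chloro, fluoro or an unsubstituted phenyl. An amine or a carboxylic acid on the phenyl ring, or a longer chain in place of 3-chloropropyl, also remains to be placed against these three compounds.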